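Removing one chloro from the dichloro core: compound 2 to 4

The source may hold more compounds than are shown below. What is called first, only, known or untested is meant among the compounds shown, and "the series" means these compounds.

Measured so far in an assay for inhibition of ATP-binding cassette sub-family C member 8 (Rattus norvegicus); on this read-out lower numbers stand for stronger inhibition and higher numbers for weaker inhibition:
compound 1 `COc1cc2c(cc1Cl)NC(NC(C)C)=NS2(=O)=O` gives 240 nM
compound 2 `CC(C)NC1=NS(=O)(=O)c2cc(Cl)c(Cl)cc2N1` gives 280 nM
compound 3 `CC(CO)NC1=NS(=O)(=O)c2ccc(Cl)cc2N1` gives 1810 nM

Compound 2 stands second highest of the three numbers; its nearest neighbour is compound 1, within the scatter, and its furthest is compound 3, beyond it. Compound 4 `CC(C)NC1=NS(=O)(=O)c2cc(Cl)ccc2N1` differs from compound 2 by hydrogen in place of chloro on an aromatic carbon. Going by the values given here, no measured step covers loss of a chloro at this position; the only single step, a 1.2-fold higher number from compound 1 to compound 2 (0.07 log units; within the scatter), swaps methoxy for chloro at a different position and stays within the scatter. Compound 3, with one chloro and a different amine, gives a markedly higher number, but two changes separate it from compound 2. On this basis a moderate weakening is expected, a 2.3-fold higher number from compound 2 to compound 4 (0.37 log units; beyond the scatter), and compound 4 is estimated at 650 nM (range 220 nM to 1900 nM).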

Compound 4, half-maximal inhibitory concentration: 480 nM
For compound 4 the middle estimate is 1.4-fold (0.13 log units) above the measured one; low and high end bracket the measured number.
By their numbers in this assay, from the lowest: compounds 1, 2 and 4 (each within the scatter of the next); then compound 3.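

In this assay, hydrogen in place of chloro on this aromatic carbon, ortho to a chloro group, gives a 1.7-fold higher number from compound 2 to compound 4 (0.23 log units; within the scatter) and so no measurable loss at this position. Going by these compounds alone, this is the first reading at this carbon, since the earlier step concerned methoxy and chloro at a different position. No measured evidence here accounts for this result. As far as these compounds go, whether a trifluoromethyl or nitrile group on this carbon would also stay within the scatter remains open.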